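This account rests on a few compounds, and the source may have more. Where it says the series, first, only, none or still open, it means among the compounds named here.

Compound 3 `Cc1cc(Nc2ccccc2)c(S(C)(=O)=O)cc1C(=O)N=C(N)N` is the reference point here. In a functional assay for inhibition of sodium/hydrogen exchanger (Oryctolagus cuniculus) (a lower number here means a stronger inhibitor, a higher number a weaker inhibitor), compound 3 gives 21 nM. Compound 1 `Cc1cc(-c2ccc(F)cc2)c(S(C)(=O)=O)cc1C(=O)N=C(N)N` gives 36 nM in this assay, and the step of a 1.7-fold lower number from compound 1 to compound 3 (0.23 log units; within the scatter) stays within the scatter, so the two cannot be ranked. Compound 2 `Cc1cc(-c2cc(Cl)cc(Cl)c2)c(S(C)(=O)=O)cc1C(=O)N=C(N)N` gives 130 nM, and compound 3 is clearly separated from it by a 6.2-fold lower number from compound 2 to compound 3 (0.79 log units; beyond the scatter); the remaining measured step is a 3.6-fold higher number from compound 1 to compound 2 (0.56 log units; beyond the scatter). Compound 4 `Cc1cc(Oc2cccnc2)c(S(C)(=O)=O)cc1C(=O)N=C(N)N` differs from compound 3 by (pyridin-3-yl)oxy in place of anilino on an aromatic carbon. For the measured compounds named here, no measured step replaces the anilino group with anything, so the nearest guide is a 1.7-fold lower number from compound 1 to compound 3 (0.23 log units; within the scatter), where exchanging the whole attached group changed little. A small step of a 1.9-fold higher number from compound 3 to compound 4 (0.28 log units; within the scatter) is therefore expected, and compound 4 is estimated at 40 nM, between 15 nM and 110 nM.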

Compound 4, half-maximal inhibitory concentration: 8.8 nM
Estimate against measurement, compound 4: 4.5-fold (0.66 log units) above, and the stated range ends above it.
By their numbers in this assay, from the lowest: compound 4; then compounds 3 and 1 (each within the scatter of the next); then compound 2.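

In this assay, compound 4 has the lowest number of the four, with its step from each of the others beyond the scatter: a 2.4-fold lower number from compound 3 to compound 4 (0.38 log units; beyond the scatter), a 4.1-fold lower number from compound 1 to compound 4 (0.61 log units; beyond the scatter) and a 15-fold lower number from compound 2 to compound 4 (1.17 log units; beyond the scatter). So this position still distinguishes between groups of the same heavy-atom count, even among the stronger inhibitors. No measurement here explains why (pyridin-3-yl)oxy gives a lower number than anilino. On these data alone, the step changes the linking atom and the ring together, so their shares remain unknown. Phenoxy and (pyridin-3-yl)amino at this position would separate the two.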